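The compounds below may be only part of what the source reports. "The series", "measured", "known", "first", "only" and "open" are said of these compounds alone.

Measured so far in an ADME assay on microsomes from liver (Homo sapiens) for metabolic stability, read by LC-MS, using NADPH, tested at 5 uM; a higher number here means that the compound lasts longer, a lower number that the compound disappears faster:
Compound 1 `Cc1cc(S(=O)(=O)/N=C(\N)N/N=C/C#Cc2ccccc2)c(SCc2ccccc2C(F)(F)F)cc1Cl` gives 0.653 h.
Compound 2 `Cc1cc(S(=O)(=O)/N=C(\N)N/N=C/C#Cc2ccccc2)c(SCc2ccccc2Cl)cc1Cl` gives 0.254 h.

For the measured compounds named here, compound 2 stands lowest of these two numbers, and its only neighbour is compound 1, since the step of a 2.6-fold lower number from compound 1 to compound 2 (0.41 log units; beyond the scatter) lies beyond the scatter. Compound 3 `Cc1cc(S(=O)(=O)/N=C(\N)N/N=C/C#Cc2ccccc2)c(SCc2cccc3ccccc23)cc1Cl` has not yet been measured. It differs from compound 2 by naphthalen-1-yl in place of 2-chlorophenyl on a saturated chain carbon bound to a sulfur. Going by the values given here, no measured step touches this place. Among the compounds with values here, the single step known, a 2.6-fold lower number from compound 1 to compound 2 (0.41 log units; beyond the scatter), swaps chloro for trifluoromethyl on an aromatic carbon and shows that even a small change can shift this assay by a modest amount. A swap of one ring for a larger one is a bigger structural change, but nothing measured says which way it should run, so the expected step for compound 3 is about a 1.2-fold higher number from compound 2 to compound 3 (0.07 log units; within the scatter), with a wide range. Compound 3 is thus estimated to give 0.3 h in this assay, between 0.12 h and 0.75 h.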

Compound 3, half-life: 1.2 h
Compound 3: middle estimate off by 4.0-fold (0.60 log units), on the low side, and the stated range ends below it.
By their numbers in this assay, from the lowest: compound 2; then compounds 1 and 3 (each within the scatter of the next).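

In this assay, the aromatic group on a saturated chain carbon bound to a sulfur clearly matters: naphthalen-1-yl in place of 2-chlorophenyl gives a 4.7-fold higher number from compound 2 to compound 3 (0.67 log units; beyond the scatter) and so undoes the loss seen with the chloro compound. Set against the 2-(trifluoromethyl)phenyl group, naphthalen-1-yl gives a 1.8-fold higher number from compound 1 to compound 3 (0.26 log units; within the scatter) and the two groups cannot be told apart here, so a second aromatic ring at this place costs no half-life relative to compound 1. Nothing measured here explains these differences.

Going by these compounds, it remains open whether this place needs an aromatic ring at all, since a cyclohexyl ring or a plain butyl chain would test that directly. A group carrying an amine or a carboxylic acid at this place also remains an open case.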